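Swapping the Thiophene Ketone for a Chlorophenyl Ketone

The source may report more compounds than this note shows. Statements on the series, on what has been measured and on what is new or still open speak of the compounds shown alone.

Measured compounds:
compound 1, `N#C/C(=C\c1c(-c2ccccc2)[nH]c2ccccc12)C(=O)c1cccs1`: 11000 nM
compound 2, `O=C(C(=Cc1c(-c2ccccc2)[nH]c2ccccc12)C(=O)c1ccccc1)c1ccccc1`: > 100000 nM

Going by the values given here, in a functional assay on DU-145 cells (Homo sapiens) for cytotoxicity, read by MTT assay, with a stated time of 96 h (on this read-out higher numbers stand for an effect only at larger amounts of compound and lower numbers for an effect already at smaller amounts), compound 1 gives 11000 nM, the only full number in the set. Compound 2 reaches only the limit of this assay, at the limit of > 100000 nM in this assay, at which 1 of the 2 values shown sits. Among the compounds with values here, since compound 1 and compound 2 differ in more than one place, no single step between them is counted, and their two values show only that compound 1 has a number while compound 2 does not.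

The untested compound 3, `N#C/C(=C\c1c(-c2ccccc2)[nH]c2ccccc12)C(=O)c1ccc(Cl)cc1`, is derived from compound 1 by one change: 4-chlorophenyl in place of thiophen-2-yl on a carbonyl carbon. Within the data shown here, both groups are aromatic rings on the same carbonyl carbon, and no measured pair in this set isolates this kind of swap, so no step size can be read from the data. The step from compound 1 to compound 3 is therefore expected to stay within the usual scatter, as a 1.1-fold higher number from compound 1 to compound 3 (0.04 log units; within the scatter). In this assay compound 3 is estimated at 12000 nM, within a range from 4000 nM to 40000 nM.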

Compound 3, half-maximal effective concentration: 11000 nM
The estimate for compound 3 lay 1.1-fold (0.04 log units) above the measured number, within the range that was stated.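

In this assay, going by these compounds alone, 4-chlorophenyl in place of thiophen-2-yl on a carbonyl carbon gives no change at the digits printed from compound 1 to compound 3 (within the scatter), the first step in this set that can be read at all. It shows that, at this place on the core of compound 1, a six-membered aromatic ring of carbon only reads the same as a five-membered aromatic ring with one hetero atom, even with sulfur leaving and chlorine entering. No measurement shown here gives a reason for this result.

Going by these compounds, it remains open how a non-aromatic group on this carbonyl carbon, such as an amine like morpholine or a carboxylic acid, would read in this assay. Within the data shown here, also open is what the nitrile contributes on its own, since no single step isolates it.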